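This account rests on a few compounds, and the source may have more. Where it says the series, first, only, none or still open, it means among the compounds named here.

Working notes on the series, assay a functional assay on MCF7 cells (Homo sapiens) for inhibition, read by MTT assay, with a stated time of 72 h; on this read-out lower numbers stand for stronger inhibition and higher numbers for weaker inhibition.

Compound 1 `Cc1cc(Nc2cc(-c3ccccc3)[nH]n2)n2nc(SCc3c(Cl)cccc3Cl)nc2n1` holds the lowest of the two numbers in this assay, at 3230 nM. Compound 3 `Cc1cc(Nc2cc(-c3ccccc3)[nH]n2)n2nc(SCc3ccc(Cl)cc3)nc2n1` stands next with 8260 nM, a change of a 2.6-fold higher number from compound 1 to compound 3 (0.41 log units; beyond the scatter). Compound 2 `Cc1cc(Nc2cc(-c3ccccc3)[nH]n2)n2nc(SCC3CCCCC3)nc2n1` gives only a limit of the assay, > 50000 nM. Against that limit the step of an at least 15-fold higher number from compound 1 to compound 2 (1.18 log units; beyond the scatter) and the step of an at least 6.0-fold lower number from compound 2 to compound 3 (0.78 log units; beyond the scatter) both rest on (the limit of > 50000 nM in this assay, at which 1 of the 3 values shown sits), so their exact sizes are open, but both point the same way: with 2,6-dichlorophenyl or 4-chlorophenyl on the chain carbon bound to sulfur a number is read, with cyclohexyl none.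

Compound 4 `C#CCSc1nc2nc(C)cc(Nc3cc(-c4ccccc4)[nH]n3)n2n1` carries the change (ethynyl in place of 2,6-dichlorophenyl on a saturated chain carbon bound to a sulfur). Among the measured compounds shown here, the one measured step that bears on it is the one from compound 1 to compound 2, where the aromatic ring was also exchanged for a group without one, at an at least 15-fold higher number from compound 1 to compound 2 (1.18 log units; beyond the scatter); the smaller step of a 2.6-fold higher number from compound 1 to compound 3 (0.41 log units; beyond the scatter) kept the ring and is less relevant. A weakening beyond the scatter is therefore expected for compound 4, with a fair chance that only a limit is read. The estimate for compound 4 is 30000 nM, between 9000 nM and 80000 nM, a step of a 9.3-fold higher number from compound 1 to compound 4 (0.97 log units; beyond the scatter).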

Compound 4, half-maximal inhibitory concentration: 21800 nM
Compound 4: the middle estimate sits 1.4-fold (0.14 log units) above what was measured, within the range that was stated.
By their numbers in this assay, from the lowest: compound 1; then compound 3; then compound 4. At a limit, above all of these: compound 2.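

With ethynyl on the saturated chain carbon bound to a sulfur a number is read again, so in this assay a group without an aromatic ring does not by itself end the read-out, as compound 2 alone might have suggested. The chlorinated aromatic groups still stay ahead, with a 6.7-fold higher number from compound 1 to compound 4 (0.83 log units; beyond the scatter) for the loss of 2,6-dichlorophenyl and a 2.6-fold higher number from compound 3 to compound 4 (0.42 log units; beyond the scatter) for the loss of 4-chlorophenyl, so the order of the read numbers holds among compounds 1, 3 and 4. Compound 2 remains a limit, and the step of an at least 2.2-fold lower number from compound 2 to compound 4 (0.36 log units; beyond the scatter) fixes only the direction of that gap, not its size: the limit of > 50000 nM in this assay, at which 1 of the 4 values shown sits.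

The compounds shown leave open how a phenyl without chlorine, or a propyl chain in place of propargyl, would stand on this carbon, so the shares of the chlorines and of the triple bond in these steps cannot be told apart. Also open, going by these compounds, is whether an amine or a carboxylic acid at the end of the chain bound to sulfur would give a read number at all.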